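Hydrazone aryl replacements on the shared core

The source may report more compounds than this note shows. Statements on the series, on what has been measured and on what is new or still open speak of the compounds shown alone.

Compound 1 `CN(C)CCn1cnnc1-c1cc(Oc2ccc(NC(=O)N/N=C/c3c(Cl)cccc3Cl)cc2F)ccn1` is the reference of this set. Among the measured compounds shown here, in a functional assay on HT-29 cells (Homo sapiens) for cytotoxicity, read by MTT assay, with a stated time of 72 h (on this read-out higher numbers stand for weaker inhibition and lower numbers for stronger inhibition), compound 1 gives 280 nM, the lowest of the three numbers measured so far. Compound 3 `CN(C)CCn1cnnc1-c1cc(Oc2ccc(NC(=O)N/N=C/c3ccc(O)c(Br)c3)cc2F)ccn1` gives 450 nM in this assay, and compound 2 `CN(C)CCn1cnnc1-c1cc(Oc2ccc(NC(=O)N/N=C/c3c[nH]c4ccccc34)cc2F)ccn1` gives 1300 nM. The step of a 1.6-fold higher number from compound 1 to compound 3 (0.21 log units; within the scatter) stays within the scatter, whereas a 4.6-fold higher number from compound 1 to compound 2 (0.67 log units; beyond the scatter) and a 2.9-fold lower number from compound 2 to compound 3 (0.46 log units; beyond the scatter) are both modest but beyond it.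

Compound 4 `CN(C)CCn1cnnc1-c1cc(Oc2ccc(NC(=O)N/N=C/c3ccccc3O[N+](=O)[O-])cc2F)ccn1` has not yet been measured. Its difference from compound 1 is 2-(nitrooxy)phenyl in place of 2,6-dichlorophenyl on a carbon with a double bond to nitrogen. Both measured steps bear on this change, since each replaces the 2,6-dichlorophenyl on the carbon with a double bond to nitrogen: one replacement left the number unchanged within the scatter, the other raised it modestly. No replacement at this position has given a lower number than compound 1. The expectation for compound 4 is therefore a small rise in this assay, possibly not beyond the scatter, with the larger rise seen for compound 2 as the upper bound.

Compound 4 is expected at 450 nM, within a range from 200 nM to 1100 nM. The expected step is a 1.6-fold higher number from compound 1 to compound 4 (0.21 log units; within the scatter).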

Compound 4, half-maximal inhibitory concentration: 950 nM
The estimate for compound 4 lay 2.1-fold (0.32 log units) below the measured number; the measured number falls inside the stated range.
By their numbers in this assay, from the lowest: compounds 1 and 3 (each within the scatter of the next); then compounds 4 and 2 (each within the scatter of the next).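

In this assay, the 2-(nitrooxy)phenyl group is a second replacement of the 2,6-dichlorophenyl on the carbon with a double bond to nitrogen that moves the number beyond the scatter, a 3.4-fold higher number from compound 1 to compound 4 (0.53 log units; beyond the scatter), which leaves the 3-bromo-4-hydroxyphenyl of compound 3 as the only replacement shown that stays within the scatter of compound 1. The new group also separates from that replacement, a 2.1-fold higher number from compound 3 to compound 4 (0.32 log units; beyond the scatter), but not from the 1H-indol-3-yl group, a 1.4-fold lower number from compound 2 to compound 4 (0.14 log units; within the scatter), so the four compounds now form two groups, compounds 1 and 3 on one side and compounds 2 and 4 on the other. No measurement in hand explains this split or connects it to the hydrogen-bond acceptors counted for the 2-(nitrooxy)phenyl group.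

Open, going by these compounds, is whether the step to compound 4 depends on the nitrooxy group itself or only on the absence of the two chlorine atoms, a question that an unsubstituted phenyl or a 2-hydroxyphenyl at this place would bear on. Also open, on these data alone, is whether the same two groups would appear in cells other than those of this single read-out.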